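Methylcarbamoyl to methoxycarbonyl: expected clearance for compound 4

A few compounds are considered here, and "the series" means these few. Any claim that something is new, unique, unknown or untested is made for them only; others in the source may bear on it.

Three compounds in this series have numbers in an in vivo ADME assay on the whole organism (Rattus norvegicus, strain Sprague Dawley) for pharmacokinetics; a higher number here means faster removal of the compound, a lower number slower removal: compound 1 `Cc1ccnc(NCc2ccc(-c3ccccc3C(=O)O)cc2)c1NC(=O)CC#N` gives 4.3 mL/min/kg, compound 2 `CNC(=O)c1ccccc1-c1ccc(CNc2ncccc2NC(=O)CC(F)(F)F)cc1` gives 15 mL/min/kg, and compound 3 `CNC(=O)c1ccccc1-c1ccc([C@@H](C)Nc2nccc(C)c2NC(=O)CC(F)(F)F)cc1` gives 31 mL/min/kg. Compound 3 stands highest of the three; its gap to compound 2 and its gap to compound 1 both lie beyond the scatter. Compound 4 `COC(=O)c1ccccc1-c1ccc([C@@H](C)Nc2nccc(C)c2NC(=O)CC(F)(F)F)cc1` has not been measured. It differs from compound 3 by methoxy in place of methylamino on a carbonyl carbon, read one bond further out as methylcarbamoyl to methoxycarbonyl. Among the measured compounds shown here, no measured pair carries this change, so nothing here tells how large a step it brings. The expectation for compound 4 is a step of a 1.1-fold higher number from compound 3 to compound 4 (0.05 log units; within the scatter) that stays within the scatter, in either direction. Compound 4 is accordingly estimated at 35 mL/min/kg, with a range from 15 mL/min/kg to 75 mL/min/kg.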

Compound 4, clearance: 8 mL/min/kg
For compound 4 the middle estimate is 4.4-fold (0.64 log units) above the measured one; measured number outside the range, below it.
By their numbers in this assay, from the lowest: compounds 1, 4 and 2 (each within the scatter of the next, the first and the last beyond it); then compound 3.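

In this assay, methoxy in place of methylamino on a carbonyl carbon gives a 3.9-fold lower number from compound 3 to compound 4 (0.59 log units; beyond the scatter). This first one-place step in the series shows that this position matters for the read-out: a swap that leaves the heavy-atom count unchanged but removes the amide hydrogen still moves the number beyond the scatter. Nothing available accounts for the direction or size of the step.

Still open, from the compounds shown here alone, is whether ethoxy or dimethylamino on the same carbonyl carbon would move the number similarly. A single pair also cannot show whether the step carries over to other compounds in the series.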